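From a Cyclohexyl Amine to a Bromophenyl Amine

This account rests on a few compounds, and the source may have more. Where it says the series, first, only, none or still open, it means among the compounds named here.

The shared core carries a single varied amine substituent. In a functional assay on MCF7 cells (Homo sapiens) for inhibition, read by sulforhodamine B assay (a higher number here means a weaker inhibitor, a lower number a stronger inhibitor), compound 1 `COc1cccc(NC2=CC(=O)c3c(nc4n3[C@H]3OC[C@@H](O)[C@H]3OC4)C2=O)c1` gives 3830 nM. Compound 2 `O=C1C(NC2CC2)=CC(=O)c2c1nc1n2[C@H]2OC[C@@H](O)[C@H]2OC1` gives only the limit > 16000 nM. Compound 3 `O=C1C(NC2CCCCC2)=CC(=O)c2c1nc1n2[C@H]2OC[C@@H](O)[C@H]2OC1` likewise gives only the limit > 16000 nM. Both of these rest on (the limit of > 16000 nM in this assay, at which 2 of the 3 values shown sit). The steps of an at least 4.1-fold higher number from compound 1 to compound 2 (0.62 log units; beyond the scatter) and an at least 4.1-fold higher number from compound 1 to compound 3 (0.62 log units; beyond the scatter) are each beyond the scatter, whereas the step that the two limits leave unreadable from compound 2 to compound 3. Compound 3 thus sits at the weaker end of what has been measured, and its number is known only as a limit.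

Compound 4 `O=C1C(Nc2ccc(Br)cc2)=CC(=O)c2c1nc1n2[C@H]2OC[C@@H](O)[C@H]2OC1` is compound 3 with 4-bromophenyl in place of cyclohexyl on an amine nitrogen. Compound 4 shares with compound 1 a six-membered aromatic ring of carbon only on the amine nitrogen, so the step of an at least 4.1-fold higher number from compound 1 to compound 3 (0.62 log units; beyond the scatter), read in reverse, is the nearest guide. Compound 4 is therefore expected to return a measurable number, with a step of an at least 3.2-fold lower number from compound 3 to compound 4 (0.50 log units; beyond the scatter). The estimate for compound 4 in this assay is 5000 nM, with a range from 1500 nM to 16000 nM.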

Compound 4, half-maximal inhibitory concentration: 4330 nM
Estimate against measurement, compound 4: 1.2-fold (0.06 log units) above; the range from low to high includes it.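

Putting 4-bromophenyl on the amine nitrogen brings back a measurable number in this assay, with an at least 3.6-fold lower number from compound 3 to compound 4 (0.56 log units; beyond the scatter) and an at least 3.6-fold lower number from compound 2 to compound 4 (0.56 log units; beyond the scatter). Compound 2 and compound 3 each carry a limit and not a number, so these two steps give only a minimum size: the limit of > 16000 nM in this assay, at which 2 of the 4 values shown sit. The aromatic ring also tolerates a change of substituent, since 4-bromophenyl and 3-methoxyphenyl read alike, with a 1.1-fold higher number from compound 1 to compound 4 (0.05 log units; within the scatter); among these four compounds, the two with a six-membered aromatic ring on this nitrogen give numbers, while the cyclopropyl and cyclohexyl compounds give only limits.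

Going by these compounds, what a plain phenyl on this nitrogen would give remains open, and with it how much the bromine or the methoxy contributes to these numbers. Whether a pyridyl ring or a benzyl group on the same nitrogen would also give a measurable number is equally unknown.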